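Chloro on the phenyl ring of compound 3: working notes

The source may report more compounds than this note shows. Statements on the series, on what has been measured and on what is new or still open speak of the compounds shown alone.

Measured in a functional assay on HOP-62 cells (Homo sapiens) for inhibition, with a stated time of 48 h (a lower number here means a stronger inhibitor of growth, a higher number a weaker inhibitor of growth), so far:
- compound 1 `COc1ccccc1/C=C/C(=O)c1c(O)cc2occc2c1OC` gives 19300 nM
- compound 2 `COc1c(C(=O)/C=C/c2ccc(Cl)cc2)c(O)c(Br)c2occc12` gives 6820 nM
- compound 3 `C=CCc1c(O)c(C(=O)/C=C/c2ccccc2)c(OC)c2ccoc12` gives 5320 nM

Compound 3 stands level with compound 2 within the scatter, while compound 1 stands at a higher number, beyond the scatter from both.

The next structure is compound 4 `C=CCc1c(O)c(C(=O)/C=C/c2ccc(Cl)cc2)c(OC)c2ccoc12` which has chloro in place of hydrogen on an aromatic carbon, para to a large group chloro in place of hydrogen on an aromatic carbon and so turns phenyl to 4-chlorophenyl. Among the measured compounds shown here, no measured pair isolates this change. For the measured compounds named here, the only guide is indirect: compound 2 also carries 4-chlorophenyl, differs elsewhere as well, and gives 6820 nM within the scatter of compound 3. No step beyond the scatter is therefore expected, and the estimated step is a 1.3-fold lower number from compound 3 to compound 4 (0.12 log units; within the scatter) in this assay with wide uncertainty. For compound 4 the expected value is 4000 nM with an estimated range from 1800 nM to 9000 nM until the measurement is available.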

Compound 4, concentration for 50% growth inhibition: 2310 nM
For compound 4 the middle estimate is 1.7-fold (0.24 log units) above the measured one; the range from low to high includes it.
By their numbers in this assay, from the lowest: compound 4; then compounds 3 and 2 (each within the scatter of the next); then compound 1.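

In this assay, among the compounds shown here, chloro in place of hydrogen on an aromatic carbon, para to a large group, gives a 2.3-fold lower number from compound 3 to compound 4 (0.36 log units; beyond the scatter), the first isolated reading of this change, and it lies beyond the scatter. With 4-chlorophenyl held constant, allyl in place of bromo on an aromatic carbon gives a 3.0-fold lower number from compound 2 to compound 4 (0.47 log units; beyond the scatter), so the level standing of compound 2 and compound 3 did not mean that chloro leaves the number unchanged on the core of compound 3. Nothing available explains either step.

Going by these compounds, whether fluoro, methoxy or an amine at this same place would give a step of similar size stays open. So does whether a longer chain in place of allyl would move the number further.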